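This account rests on a few compounds, and the source may have more. Where it says the series, first, only, none or still open, it means among the compounds named here.

Compound 1 `Cc1ccccc1-c1nn(-c2ccc(Br)cc2)cc1CNCCN1CCN(C)CC1`: 9600 nM
Compound 2 `CCOC(=O)Cn1cc(CNCCN2CCN(C)CC2)c(-c2ccccc2C)n1`: > 20000 nM

Both numbers come from an ADME assay on Huh-7 cells (Homo sapiens) for cytotoxicity; a higher number here means that more compound is tolerated, a lower number that less compound is tolerated. For compound 2 the value is only a limit of the assay, at the limit of > 20000 nM in this assay, at which 1 of the 2 values shown sits, so its position is known only as a range and not as a number. Among the measured compounds shown here, the single measured step, an at least 2.0-fold higher number from compound 1 to compound 2 (0.31 log units; beyond the scatter), bears on the change to compound 3 `Cc1ccccc1-c1nn(-c2ccc(N)cc2)cc1CNCCN1CCN(C)CC1`, which carries 4-aminophenyl in place of (ethoxycarbonyl)methyl on an aromatic nitrogen. That measured step exchanged 4-bromophenyl for (ethoxycarbonyl)methyl on the aromatic nitrogen and raised the number; the change to compound 3 puts an aryl group back on the same nitrogen, so the number is expected to fall back toward that of compound 1, by a modest step at most. Compound 3 is therefore expected to give 14000 nM in this assay, within 6000 nM to 30000 nM. The expected step is an at least 1.4-fold lower number from compound 2 to compound 3 (0.15 log units; that floor lies within the scatter), with the range kept wide since compound 2 is known only as a limit.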

Compound 3, half-maximal cytotoxic concentration: > 20000 nM
Compound 3: only a limit was reported; the forecaster's own chance of this, stated with the estimate: 35%; middle value at least 1.4-fold (0.15 log units) from the limit.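

In this assay, the change of bromo to amino on an aromatic carbon gives an at least 2.0-fold higher number from compound 1 to compound 3 (0.31 log units; beyond the scatter), so an aryl group on this aromatic nitrogen does not by itself hold the number down. Among the two aryl groups shown, the outcome therefore depends on the substituent: the 4-bromophenyl group gives the only numerical value of the three compounds, whereas the 4-aminophenyl group, like (ethoxycarbonyl)methyl, gives a value that is only a limit. The step between compound 2 and compound 3 cannot be read because both values stand at the same limit: the limit of > 20000 nM in this assay, at which 2 of the 3 values shown sit.

As far as these compounds go, how far compound 2 and compound 3 lie beyond that limit remains open. From the compounds shown here alone, it is also open whether chloro, methyl or hydroxyl in place of bromo would give a number like that of compound 1 or a limit like that of compound 3.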